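The source may report more compounds than this note shows. Statements on the series, on what has been measured and on what is new or still open speak of the compounds shown alone.

Measured in a functional assay on CCRF-CEM cells (Homo sapiens) for cytotoxicity, in the presence of a further agent that is not named here; on this read-out lower numbers stand for stronger inhibition and higher numbers for weaker inhibition:
- compound 1 `COC(=O)c1ccc(CN(CCCc2c(N)nc(N)nc2O)c2cc(F)cc(F)c2[N+](=O)[O-])cc1`: > 100000 nM (a limit of the assay)
- compound 2 `COC(=O)c1ccc(CN(CCCc2c(N)nc(N)nc2O)c2ccc([N+](=O)[O-])c(F)c2F)cc1`: 45000 nM
- compound 3 `COC(=O)c1ccc(CN(CCCc2c(N)nc(N)nc2O)c2cc(F)ccc2[N+](=O)[O-])cc1`: 30000 nM

Only two of these results are actual numbers, and they lie close together: a 1.5-fold lower number from compound 2 to compound 3 (0.18 log units; within the scatter). Compound 4 `Nc1nc(N)c(CCCNc2ccc([N+](=O)[O-])c(F)c2F)c(O)n1` has hydrogen in place of 4-(methoxycarbonyl)benzyl on a nitrogen on an aromatic ring. Within the data shown here, no measured step touches that group. The nearest guides change only the nitrophenyl group: an at least 2.2-fold lower number from compound 1 to compound 2 (0.34 log units; beyond the scatter), and an at least 3.3-fold lower number from compound 1 to compound 3 (0.52 log units; beyond the scatter). Both are at least modest, so they offer only a rough scale. A modest step towards a higher number, meaning weaker inhibition, is expected from compound 2 at 45000 nM. The estimated step is a 1.6-fold higher number from compound 2 to compound 4 (0.19 log units; within the scatter). For compound 4 the estimate is 70000 nM, with an expected range of 20000 nM to 150000 nM.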

Compound 4, half-maximal inhibitory concentration: 73000 nM
The estimate for compound 4 lay 1.0-fold (0.02 log units) below the measured number, and the stated range covers the measured number.
By their numbers in this assay, from the lowest: compounds 3, 2 and 4 (each within the scatter of the next, the first and the last beyond it). At a limit, above all of these: compound 1.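

Putting hydrogen in place of 4-(methoxycarbonyl)benzyl on this nitrogen gives a 1.6-fold higher number from compound 2 to compound 4 (0.21 log units; within the scatter) in this assay, so the two compounds cannot be told apart. This is the first change shown at this position, and the whole group can go without a step beyond the scatter, although both numbers are high. Compound 1 remains a limit, not a number: the limit of > 100000 nM in this assay, at which 1 of the 4 values shown sits.

Going by these compounds, whether a plain benzyl, a carboxylic acid or an amine on a longer chain at this nitrogen would give a clearly lower number stays open. So does whether hydrogen there behaves the same with the 5-fluoro-2-nitrophenyl group.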